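The source may hold more compounds than are shown below. What is called first, only, known or untested is meant among the compounds shown, and "the series" means these compounds.

Working notes on the series. Compound 1 `CCCCCCCCCCCCNC(=O)[C@@H](NC(=O)c1ccco1)[C@@H](C)O` is the furan-2-yl amide of the shared core. Among the measured compounds shown here, in a functional assay on HepG2 cells (Homo sapiens) for cytotoxicity, read by MTT assay, with a stated time of 48 h (on this read-out lower numbers stand for stronger inhibition and higher numbers for weaker inhibition), compound 1 gives 147000 nM, which is the only plain number the series holds so far. Compound 2 `C/C=C/C=C/C(=O)N[C@H](C(=O)NCCCCCCCCCCCC)[C@@H](C)O` is the penta-1,3-dien-1-yl analogue. In this assay compound 2 reads > 400000 nM, a limit of the assay and not a number. For the measured compounds named here, the one measured step, an at least 2.7-fold higher number from compound 1 to compound 2 (0.43 log units; beyond the scatter), exchanges the group on the carbonyl carbon, and its end point sits at the limit of > 400000 nM in this assay, at which 1 of the 2 values shown sits.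

Compound 3 `CCCCCCCCCCCCCCCCCCNC(=O)[C@@H](NC(=O)c1ccco1)[C@@H](C)O` departs from compound 1 at a different place: hexyl in place of hydrogen on a saturated chain carbon, ten or more bonds along the chain from an amide-type nitrogen. Going by the values given here, no measured step touches this chain, so the step from compound 1 to compound 2 bears on it only as a reminder that the series can run past the upper limit, not as a guide to direction. With nothing to set a direction, the expected step is none beyond the scatter, and compound 1 to compound 3 is estimated at a 1.1-fold lower number from compound 1 to compound 3 (0.02 log units; within the scatter). In this assay compound 3 is accordingly estimated at 140000 nM, with a range from 45000 nM to 400000 nM, and a real chance that only a limit is returned.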

Compound 3, half-maximal inhibitory concentration: 42300 nM
Compound 3: the middle estimate sits 3.3-fold (0.52 log units) above what was measured; measured number outside the range, below it.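

The chain is not a silent position: in this assay, hexyl in place of hydrogen on a saturated chain carbon, ten or more bonds along the chain from an amide-type nitrogen, gives a 3.5-fold lower number from compound 1 to compound 3 (0.54 log units; beyond the scatter) and so marks a modest step. Among the compounds shown here, with the furan-2-yl amide held constant, this far part of the chain, which no earlier step touched, moves the read-out toward lower numbers, whereas the measured change on the carbonyl carbon moves it toward higher numbers. The data shown hold nothing that bears on the reason for this step.

As far as these compounds go, a single step on the chain sets no trend, so it stays open whether the numbers keep falling with a chain longer than that of compound 3 or rise with one shorter than that of compound 1. Also open, from the compounds shown here alone, are whether the same chain change holds with the penta-1,3-dien-1-yl amide of compound 2 and how an amine or a carboxylic acid at the far end of the chain would read.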